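The compounds below may be only part of what the source reports. "The series", "measured", "known", "first", "only" and "open" are said of these compounds alone.

In an in vitro assay on HEK385-7 cells for displacement of a labelled ligand from prostaglandin D2 receptor 2 (Homo sapiens) (a higher number here means a weaker inhibitor, a lower number a stronger inhibitor), compound 1 `Nc1nc(-c2ccc(Cl)cc2)c(CC(=O)O)s1` returns only a limit, > 100000 nM, which is a limit of the assay and not a number (the limit of > 100000 nM in this assay, at which 1 of the 3 values shown sits). In this assay compound 2 `CCC(c1ccccc1)c1nc(-c2ccc(Cl)cc2)c(CC(=O)O)s1` gives 190 nM. Compound 3 `O=C(O)Cc1sc(C(c2ccc(F)cc2)c2ccc(F)cc2)nc1-c1ccco1` gives 18 nM in this assay, the lowest of the two numbers shown; its gap to compound 2 lies beyond the usual scatter of repeated measurements. Compound 1 stands apart, since its value is a limit.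

Compound 4 `COc1cc(-c2nc(C(c3ccc(F)cc3)c3ccc(F)cc3)sc2CC(=O)O)ccn1` has not yet been measured in this assay. It differs from compound 3 in one place only: 2-methoxypyridin-4-yl in place of furan-2-yl on an aromatic carbon, in words 2-methoxypyridin-4-yl in place of furan-2-yl on an aromatic carbon. Among the compounds with values here, no pair among the measured compounds differs only at this place, so no measured step can be pointed to for the size of the change. The expected step from compound 3 to compound 4 in this assay is therefore a small one, within the scatter, leaning if anything toward a lower number: a 1.8-fold lower number from compound 3 to compound 4 (0.26 log units; within the scatter). On this basis compound 4 is estimated to give 10 nM in this assay, with a likely range from 2.5 nM to 40 nM.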

Compound 4, half-maximal inhibitory concentration: 29 nM
Compound 4: middle estimate off by 2.9-fold (0.46 log units), on the low side; the measured number falls inside the stated range.
By their numbers in this assay, from the lowest: compounds 3 and 4 (each within the scatter of the next); then compound 2. At a limit, above all of these: compound 1.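

Within the data shown here, at the place on an aromatic carbon next to the ring nitrogen and next to the ring atom that bears a carboxymethyl group, the exchange of furan-2-yl for 2-methoxypyridin-4-yl gives in this assay a 1.6-fold higher number from compound 3 to compound 4 (0.21 log units; within the scatter) and so offers the first reading of a change at this place. It shows that, in this one pair, a five-membered aromatic ring can give way to a six-membered aromatic ring with more heavy atoms and one more hydrogen-bond acceptor without a step beyond the scatter, although a single pair sets no pattern for other groups here. Nothing measured on either group bears on why the step is this size, so the result stands without an explanation.

The two groups differ in ring size, ring hetero atom and the methoxy group all at once, so the compounds shown cannot tell what each of these contributes, and a pyridin-4-yl without the methoxy group would separate them. On these data alone, it also remains open how this place responds to a plain phenyl ring, an amine or a longer alkyl chain, or to any of these on a core that carries a different large group.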